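Swapping the thiophene ketone for a dimethoxyphenyl ketone

The source may report more compounds than this note shows. Statements on the series, on what has been measured and on what is new or still open speak of the compounds shown alone.

Compound 3 `O=C(/C=C/c1cn(-c2ccccc2)nc1-c1ccncc1)c1ccsc1` gives 1500 nM in a functional assay on MCF7 cells (Homo sapiens) for inhibition, read by sulforhodamine B assay, with a stated time of 72 h (on this read-out lower numbers stand for stronger inhibition and higher numbers for weaker inhibition), the highest of the three numbers measured; compound 2 `COc1ccc(C(=O)/C=C/c2cn(-c3ccccc3)nc2-c2cccnc2)c(OC)c1OC` with 1400 nM lies within the scatter of it, while compound 1 `O=C(/C=C/c1cn(-c2ccccc2)nc1-c1cccnc1)c1ccsc1` with 500 nM stands furthest away, as the step of a 3.0-fold higher number from compound 1 to compound 3 (0.48 log units; beyond the scatter) shows. Compound 4 `COc1ccc(C(=O)/C=C/c2cn(-c3ccccc3)nc2-c2ccncc2)c(OC)c1` differs from compound 3 by 2,4-dimethoxyphenyl in place of thiophen-3-yl on a carbonyl carbon. Among the compounds with values here, no measured step covers exactly this change; the closest comparison is compound 1 against compound 2, where a methoxy-bearing phenyl ketone in place of the thiophene ketone gives compound 2 a higher number than compound 1. A modest rise is therefore expected for compound 4, a 2.0-fold higher number from compound 3 to compound 4 (0.30 log units; within the scatter), giving an estimated 3000 nM with a likely range from 1200 nM to 7500 nM.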

Compound 4, half-maximal inhibitory concentration: 8800 nM
Beside the measured number, compound 4's estimate is 2.9-fold (0.47 log units) below it; the whole stated range lies below it.
By their numbers in this assay, from the lowest: compound 1; then compounds 2 and 3 (each within the scatter of the next); then compound 4.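

The group on the carbonyl carbon matters: with pyridin-4-yl held fixed, 2,4-dimethoxyphenyl in place of thiophen-3-yl weakens inhibition (a 5.9-fold higher number from compound 3 to compound 4 (0.77 log units; beyond the scatter)), a change beyond the usual scatter. This pair isolates the ketone group, exchanging a five-membered sulfur ring for a larger carbon ring carrying two methoxy groups. Nothing available explains the loss. Open, going by these compounds, is whether plain phenyl would keep the thiophene's level, and whether phenyl bearing one methoxy, an amine or a carboxylic acid would be tolerated on this carbonyl carbon.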